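Fluorine Gives Way to Methyl on the Benzamide Ring

The compounds below may be only part of what the source reports. "The series", "measured", "known", "first", "only" and "open" are said of these compounds alone.

Among the measured compounds shown here, in an assay on CHO cells with metabotropic glutamate receptor 5 (Homo sapiens) as the target (a higher number here means that more compound is needed for the effect, a lower number that less compound is needed), compound 2 `O=C(Nc1cc(-c2ccccc2)nn1-c1ccccc1)c1cccc(F)c1` gives 20 nM, the lowest of the two numbers measured so far. Its nearest neighbour, compound 1 `O=C(Nc1cc(-c2ccccc2)nn1-c1ccccc1)c1ccc(F)cc1`, gives 30 nM in this assay. For the measured compounds named here, the one measured step, a 1.5-fold lower number from compound 1 to compound 2 (0.18 log units; within the scatter), lies within the scatter. Compound 3 `Cc1ccccc1C(=O)Nc1cc(-c2ccccc2)nn1-c1ccccc1` has not yet been measured. It differs from compound 2 in one place: 2-methylphenyl in place of 3-fluorophenyl on a carbonyl carbon. Going by the values given here, no measured step bears directly on this change: the only known step exchanges the place of a fluorine on the ring and stays within the scatter, and no step exchanges a fluorine for a methyl group. The expectation therefore rests on the two ring groups carrying the same count of heavy atoms. Compound 3 is expected to show a step of a 1.8-fold higher number from compound 2 to compound 3 (0.24 log units; within the scatter) of no more than the scatter, and its value in this assay is estimated at 35 nM, within a range from 10 nM to 120 nM.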

Compound 3, half-maximal effective concentration: > 10000 nM
Compound 3 gave a limit, no number; the forecaster's own chance of this, stated with the estimate: 5%; at least 280-fold (2.45 log units) between middle value and limit.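

In this assay compound 3 carries a limit of the assay and not a number: the limit of > 10000 nM in this assay, at which 1 of the 3 values shown sits.

An equal count of heavy atoms did not hold the value steady at this place on the carbonyl carbon: 2-methylphenyl in place of 3-fluorophenyl brings an at least 500-fold higher number from compound 2 to compound 3 (2.69 log units; beyond the scatter), and 2-methylphenyl in place of 4-fluorophenyl brings an at least 330-fold higher number from compound 1 to compound 3 (2.52 log units; beyond the scatter). The earlier compounds showed only a 1.5-fold lower number from compound 1 to compound 2 (0.18 log units; within the scatter), so this is the first change shown to matter at this place.

On these data alone, whether the large step follows the methyl group itself or its place on the ring stays open, since the exchange alters both at once. A 2-fluorophenyl or a 3-methylphenyl group on the same carbonyl carbon would separate the two.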